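The compounds below may be only part of what the source reports. "The series", "measured", "known", "first", "only" and "open" are said of these compounds alone.

Measured in a functional assay on RAW264.7 cells (Mus musculus) for inhibition, read by Griess assay, with stated times of 1 h and 24 h; on this read-out higher numbers stand for weaker inhibition and lower numbers for stronger inhibition:
- Compound 1 `O=C1OC(Cc2nc(-c3ccccc3)no2)c2ccccc21`: > 10000 nM
- Compound 2 `CCCOc1ccc(C(O)C2OC(=O)c3c(OC)cc(OC)cc32)cc1`: 9260 nM

The entry for compound 1 is a limit of the assay, not a number. Among the measured compounds shown here, compound 2 therefore carries the only numerical value in the set, and no second number exists against which to rank it.

Compound 3 `COCCCOc1ccc(C(O)C2OC(=O)c3c(OC)cc(OC)cc32)cc1` keeps the core of compound 2 and changes only the alkoxy chain: methoxy in place of hydrogen on a saturated chain carbon, three bonds along the chain from an oxygen on an aromatic ring. Propyl becomes 3-methoxypropyl.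

For the measured compounds named here, no measured step in this set shows what such a chain change does in this assay. The expectation therefore starts from compound 2 at 9260 nM, with no step beyond the scatter foreseen in either direction. The estimated 1.2-fold lower number from compound 2 to compound 3 (0.06 log units; within the scatter) is small. For compound 3 the expected value is 8000 nM, with an estimated range of 3000 nM to 16000 nM.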

Compound 3, half-maximal inhibitory concentration: 1260 nM
Estimate against measurement, compound 3: 6.3-fold (0.80 log units) above, outside the stated range (below it).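

In this assay the alkoxy chain on the shared core proves to be a place where the read-out responds: methoxy in place of hydrogen on a saturated chain carbon, three bonds along the chain from an oxygen on an aromatic ring, gives a 7.3-fold lower number from compound 2 to compound 3 (0.87 log units; beyond the scatter). Among the compounds shown here, compound 1 and compound 2 differ in more than one place and could not show this; propyl to 3-methoxypropyl is the only one-place change in the set, and it runs towards stronger inhibition. Nothing measured in this set gives a reason for the step.

Going by these compounds, whether the chain oxygen or the added length carries the step stays open, and a plain butyl or pentyl chain would separate the two. Also open, on these data alone, is how an amine or a carboxylic acid in place of the methoxy would read.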